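The source may report more compounds than this note shows. Statements on the series, on what has been measured and on what is new or still open speak of the compounds shown alone.

In a functional assay on MDA-MB-468 cells (Homo sapiens) for inhibition, read by sulforhodamine B assay, with a stated time of 48 h (a lower number here means a stronger inhibitor of growth, a higher number a weaker inhibitor of growth), compound 3 `COc1cc(-c2nn(-c3cccc(NC(=O)Nc4cccc(C(F)(F)F)c4)c3)cc2-c2ccncc2)ccc1Cl` gives 598 nM, the lowest of the three numbers, with compound 1 `O=C(Nc1cccc(-n2cc(-c3ccncc3)c(-c3ccc(Cl)c(O)c3)n2)c1)Nc1ccc(Cl)c(Cl)c1` at 729 nM within the scatter of it and compound 2 `COc1cc(-c2nn(-c3cccc(NC(=O)c4ccc(Cl)c(C(F)(F)F)c4)c3)cc2-c2ccncc2)ccc1Cl` at 3690 nM beyond it. Compound 4 `COc1cc(-c2nn(-c3cccc(NC(=O)c4ccccc4)c3)cc2-c2ccncc2)ccc1Cl` differs from compound 3 in one place: phenyl in place of (3-(trifluoromethyl)phenyl)amino on a carbonyl carbon. Going by the values given here, the only measured step that bears on this change is a 6.2-fold lower number from compound 2 to compound 3 (0.79 log units; beyond the scatter), where the group on the carbonyl carbon went from 4-chloro-3-(trifluoromethyl)phenyl to (3-(trifluoromethyl)phenyl)amino. Compound 4 runs that step backwards, putting a phenyl straight on the carbonyl carbon, and it also drops the trifluoromethyl present in both measured neighbours, so a rise beyond the scatter is expected, an 8.4-fold higher number from compound 3 to compound 4 (0.92 log units; beyond the scatter). Compound 4 is therefore estimated at 5000 nM, with a range of 1500 nM to 20000 nM.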

Compound 4, concentration for 50% growth inhibition: 349 nM
Estimate against measurement, compound 4: 14-fold (1.16 log units) above; the measured number lies below the stated range.
By their numbers in this assay, from the lowest: compounds 4, 3 and 1 (each within the scatter of the next, the first and the last beyond it); then compound 2.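

In this assay, the change to phenyl gives a 1.7-fold lower number from compound 3 to compound 4 (0.23 log units; within the scatter), so on this carbonyl carbon the (3-(trifluoromethyl)phenyl)amino group can give way to plain phenyl with no change beyond the scatter. Phenyl in place of 4-chloro-3-(trifluoromethyl)phenyl gives an 11-fold lower number from compound 2 to compound 4 (1.02 log units; beyond the scatter), so the low numbers on this carbonyl carbon do not depend on the amino nitrogen. No measured evidence here explains either step. Still open, going by these compounds, is whether a phenyl bearing a single chloro or a single trifluoromethyl would read like compound 2 or like compound 4. Also open, on these data alone, is how a pyridine or a cyclohexyl on this carbonyl carbon would read.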